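A Dimethylamino Step from Compound 2 to Compound 4

The source may hold more compounds than are shown below. What is called first, only, known or untested is meant among the compounds shown, and "the series" means these compounds.

Measured in a physicochemical assay for solubility, read by spectrophotometry, with stated times of 1 h and 30 min; on this read-out higher numbers stand for higher solubility and lower numbers for lower solubility:
Compound 1 `COc1ccccc1/C=C/C=C/C(=O)c1ccccc1Cl`: 9.45 ug/mL
Compound 2 `O=C(/C=C/C=C/c1ccccc1)c1ccccc1Cl`: 8.2 ug/mL
Compound 3 `CC(C)c1ccc(C(=O)/C=C/C=C/c2ccccc2)cc1`: 6.78 ug/mL

The three values lie within the scatter of one another, so compound 2, at 8.2 ug/mL, cannot be set apart from either of the other two compounds. The change under consideration leads to compound 4 `CN(C)c1ccc(/C=C/C=C/C(=O)c2ccccc2Cl)cc1`, with dimethylamino in place of hydrogen on an aromatic carbon. Among the measured compounds shown here, only one measured step changes a single place, and it is a 1.2-fold lower number from compound 1 to compound 2 (0.06 log units; within the scatter). That step exchanges methoxy for hydrogen and stays within the scatter. Compound 3 differs from compound 2 in more than one place, so it offers no clean comparison, although compound 3 at 6.78 ug/mL shows the same narrow spread. For the measured compounds named here, no measured step involves dimethylamino, so the evidence is indirect. In this assay, no change beyond the scatter is therefore expected, and no direction is firmly indicated. The expected step is a 1.3-fold lower number from compound 2 to compound 4 (0.10 log units; within the scatter). For compound 4 the estimate is 6.5 ug/mL, with an expected range from 3 ug/mL to 13 ug/mL.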

Compound 4, solubility: 7.55 ug/mL
Compound 4: middle estimate off by 1.2-fold (0.07 log units), on the low side; low and high end bracket the measured number.
By their numbers in this assay, from the lowest: compounds 3, 4, 2 and 1 (each within the scatter of the next).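

In this assay, dimethylamino in place of hydrogen, on an aromatic carbon para to a large group, gives a 1.1-fold lower number from compound 2 to compound 4 (0.04 log units; within the scatter). Among the compounds shown here, this is the first direct reading for a nitrogen-bearing group at this place, and a group of 3 heavy atoms stays within the scatter, as does the only other single-place step, a 1.2-fold lower number from compound 1 to compound 2 (0.06 log units; within the scatter), which concerns methoxy and hydrogen. No separate evidence bears on this result.

From the compounds shown here alone, whether the number would stay within the scatter with a carboxylic acid or a longer amine chain at this place remains open. Also open, going by these compounds, is whether dimethylamino on a different aromatic carbon would give a similar reading in this assay.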